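The source may report more compounds than this note shows. Statements on the series, on what has been measured and on what is new or still open speak of the compounds shown alone.

Among the compounds with values here, in a functional assay on MCF7 cells (Homo sapiens), tested at 7.5 uM (a lower number here means a stronger effect, a higher number a weaker effect of the compound at the concentration tested), compound 2 `Cc1c(C)c2c(c(C)c1OCc1ccccc1)CCC(C)(COc1ccc(/C=C3\SC(=O)NC3=O)cc1)O2` gives 12%, the lowest of the two numbers measured so far; compound 1 `CCOc1cc(/C=C2\SC(=O)NC2=O)ccc1OCC1(C)CCc2c(C)c(OCC=C(C)C)c(C)c(C)c2O1` gives 54% in the same assay, a gap that lies beyond the scatter. Compound 3 `C=CCOc1c(C)c(C)c2c(c1C)CCC(C)(COc1ccc(/C=C3\SC(=O)NC3=O)cc1)O2` has not yet been measured. It differs from compound 2 by vinyl in place of phenyl on a saturated chain carbon bound to an oxygen on an aromatic ring. Within the data shown here, no measured pair isolates this change, so its size rests on expectation alone. The step is expected to weaken the effect, estimated as a number 18 percentage points higher from compound 2 to compound 3 (beyond the scatter), beyond the scatter. For compound 3 the estimated value in this assay is 30%, with a range from 10% to 60%.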

Compound 3, a percentage reported as activity, at one concentration (the size of the read-out at that concentration, not a potency): 2%
Beside the measured number, compound 3's estimate is 28 percentage points above it, and the stated range ends above it.
By their numbers in this assay, from the lowest: compounds 3 and 2 (each within the scatter of the next); then compound 1.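

In this assay, vinyl in place of phenyl on a saturated chain carbon bound to an oxygen on an aromatic ring gives a number 10 percentage points lower from compound 2 to compound 3 (within the scatter) at this position, so benzyloxy and allyloxy are not separated by this read-out. The aromatic ring of the benzyl group is therefore not needed to keep the effect seen with compound 2. Nothing available explains this result.
Open, on these data alone, is whether a propyl chain, which keeps the length of allyl without its double bond, would hold the effect here. A carboxylic acid or an amine at the end of this chain is equally untested in these compounds.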